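Aryl amide in place of cyclopentyl: tolerance outlook

A few compounds are considered here, and "the series" means these few. Any claim that something is new, unique, unknown or untested is made for them only; others in the source may bear on it.

Compound 1 `COc1ccc(-c2cnc(NC(=O)C3CCCC3)n2C)cc1`: > 100000 nM
Compound 2 `COc1ccc(-c2cn(C)c(NC(=O)c3ccc(F)cc3)n2)cc1`: > 50000 nM
Compound 3 `COc1ccc(-c2cnc(NC(=O)c3ccc(F)cc3)[nH]2)cc1`: > 100000 nM

The three measured compounds share one core and were examined in a toxicity assay on THP-1 cells (Homo sapiens) for inhibition; a lower number here means that less compound is tolerated, a higher number that more compound is tolerated. In this assay compound 1 gives > 100000 nM, which is a limit of the assay and not a number. Compound 2 gives a limit in this assay as well, namely > 50000 nM. Compound 3 likewise gives a limit in this assay, > 100000 nM. Compound 1 therefore stands only at a limit, and no measured value in this set is a number: two sit at the limit of > 100000 nM in this assay, at which 2 of the 3 values shown sit, and one at the limit of > 50000 nM in this assay, at which 1 of the 3 values shown sits. Among the compounds with values here, no step between measured compounds that differ in one place exists here.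

Compound 4 `COc1ccc(-c2cnc(NC(=O)c3ccc(O)cc3)n2C)cc1` has not yet been measured in this assay. It differs from compound 1 in one place: 4-hydroxyphenyl in place of cyclopentyl on a carbonyl carbon. Given that compound 1 sits at > 100000 nM and compounds 2 and 3 both also sit at limits, the author expects no step beyond the scatter from compound 1 to compound 4, so that a number no higher from compound 1 to compound 4 (the limit leaves the size open) is the expected change. For compound 4 the estimated value in this assay is 100000 nM, with an expected range from 50000 nM to 300000 nM, most likely reported again only as a limit.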

Compound 4, half-maximal cytotoxic concentration: > 100000 nM
Compound 4 ended at the assay's limit; the forecaster's own chance of this, stated with the estimate: 80%; the middle value lies on the limit itself.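

In this assay compound 4 gives > 100000 nM, a limit of the assay and not a number. Within the data shown here, compound 1 gives > 100000 nM, likewise a limit, so no step from compound 1 to compound 4 can be read. The compounds shown leave open where the half-maximal cytotoxic concentration of either lies, and whether 4-hydroxyphenyl in place of cyclopentyl changes it.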